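Morpholine amides on two cores: expected outcome for compound 4

The compounds below may be only part of what the source reports. "The series", "measured", "known", "first", "only" and "open" are said of these compounds alone.

Compound 1 `CNC(=O)/C=C/c1ccncc1-c1ccc2ccccc2c1` carries a methylcarbamoyl group on the shared core and, in an assay on a protein complex for inhibition of CDK8/Cyclin C (Homo sapiens), with a stated time of 1 h (a lower number here means a stronger inhibitor, a higher number a weaker inhibitor), compound 1 gives 12.4 nM. Compound 2 `CNC(=O)/C=C/c1ccncc1-c1ccc2cnn(C)c2c1` keeps the same methylcarbamoyl group on a different core; in this assay compound 2 gives 122 nM. The difference between the two cores is not broken down here. Compound 3 `O=C(/C=C/c1ccncc1-c1ccc2ccccc2c1)N1CCOCC1` is the morpholine amide of compound 1, with the change (morpholin-4-yl in place of methylamino on a carbonyl carbon). In this assay compound 3 gives 60.3 nM, a step of a 4.9-fold higher number from compound 1 to compound 3 (0.69 log units; beyond the scatter).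

Compound 4 `Cn1ncc2ccc(-c3cnccc3/C=C/C(=O)N3CCOCC3)cc21` is the unmeasured morpholine amide on the core of compound 2, made by morpholin-4-yl in place of methylamino on a carbonyl carbon, the same change as seen between compound 1 and compound 3, at the same place. Among the measured compounds shown here, the single known instance of this change gives the only basis for expectation. Starting from compound 2, compound 4 is expected to follow the weakening seen from compound 1 to compound 3, with a step of about a 4.1-fold higher number from compound 2 to compound 4 (0.61 log units; beyond the scatter). Compound 4 is therefore estimated at 500 nM in this assay. For compound 4 the expected range runs from 200 nM to 1500 nM.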

Compound 4, half-maximal inhibitory concentration: 853 nM
For compound 4 the middle estimate is 1.7-fold (0.23 log units) below the measured one, and the stated range covers the measured number.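

In this assay, morpholin-4-yl in place of methylamino on the carbonyl carbon gives a 7.0-fold higher number from compound 2 to compound 4 (0.84 log units; beyond the scatter), and the size of the step does not measurably depend on which of the two cores carries it: the same change on two cores in this assay, a 4.9-fold higher number (0.69 log units; beyond the scatter) from compound 1 to compound 3 and a 7.0-fold higher number (0.84 log units; beyond the scatter) from compound 2 to compound 4, 1.4-fold (0.16 log units) apart, within the scatter of two such steps

On these two cores, the morpholine amide is the weaker partner of each pair, and the gap between the cores survives the change. Among the compounds shown here, this rests on only two pairs in one assay, so it does not show that the step would hold on a third core or for a different amide group, and it gives no reason for the loss.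

The compounds shown leave open which part of the change carries the step, as the loss of the amide hydrogen and the entry of the ring arrive together. A dimethylamino or piperidin-1-yl group on the same carbonyl carbon, on either core, would help to separate the two.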